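Cytotoxicity notes on a fused bicyclic amine series

A few compounds are considered here, and "the series" means these few. Any claim that something is new, unique, unknown or untested is made for them only; others in the source may bear on it.

All numbers here come from an ADME assay on HOS cells (Homo sapiens) for cytotoxicity; on this read-out higher numbers stand for lower toxicity in this test and lower numbers for higher toxicity in this test.

compound 1 `CCCN(Cc1cn2c(N3CCN(C)CC3)cccc2n1)[C@H]1CCCc2cccnc21` — 6700 nM
compound 2 `CN(C)[C@H]1CCN(c2cccc3nc(CN(C)[C@H]4CCCc5cccnc54)cn23)C1` — 2100 nM
compound 3 `CN1CCN(c2cccn3cc(CN(C)[C@H]4CCCc5cccnc54)nc23)CC1` — > 5000 nM

The value of compound 3 in this assay is a limit of the assay, not a number. Among the two numbers, compound 2 stands lowest; the nearest is compound 1, whose number is higher by more than the usual scatter. Among the measured compounds shown here, no two measured compounds differ in one place, so no measured step is at hand.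

Compound 4 `CNCCN(C)c1cccc2nc(CN(C)[C@H]3CCCc4cccnc43)cn12` has not yet been measured in this assay. It differs from compound 2 in one place: methyl(2-(methylamino)ethyl)amino in place of 3-(dimethylamino)pyrrolidin-1-yl on an aromatic carbon. For the measured compounds named here, with no measured step to lean on, only a modest change is expected, if anything toward a higher number, and a result within the scatter of compound 2 would not surprise. For compound 4 the estimate in this assay is 3500 nM, with a range from 1200 nM to 10000 nM. The expected step is a 1.7-fold higher number from compound 2 to compound 4 (0.22 log units; within the scatter).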

Compound 4, half-maximal cytotoxic concentration: 2200 nM
Estimate against measurement, compound 4: 1.6-fold (0.20 log units) above; the measured number falls inside the stated range.
By their numbers in this assay, from the lowest: compounds 2 and 4 (each within the scatter of the next); then compound 1.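

In this assay, methyl(2-(methylamino)ethyl)amino in place of 3-(dimethylamino)pyrrolidin-1-yl, on an aromatic carbon next to the ring nitrogen, gives a 1.0-fold higher number from compound 2 to compound 4 (0.02 log units; within the scatter). Among the compounds shown here, this is the first measured step, and it shows that at this position the five-membered ring and its defined stereocentre can give way to an open chain with one hydrogen-bond donor while the number stays within the scatter. Nothing measured here accounts for this outcome.

Going by these compounds, whether a longer chain, a primary amine or a carboxylic acid at this position would also leave the number within the scatter of compound 2 remains open. Also open, on these data alone, is whether the same change would give a similar step with the amine side chain of compound 1.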